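Nitro in Place of Bromo: Expected Cytotoxicity of Compound 4

A few compounds are considered here, and "the series" means these few. Any claim that something is new, unique, unknown or untested is made for them only; others in the source may bear on it.

The study measures cytotoxicity in a functional assay on QGY7701 cells (Homo sapiens) for cytotoxicity, read by MTT assay, with a stated time of 48 h; a higher number here means a weaker inhibitor, a lower number a stronger inhibitor. Compound 3 `C#CCOc1ccc2c(=O)ccoc2c1` is the smallest member, and in this assay compound 3 gives 58500 nM. Compound 1 `O=c1ccoc2cc(OCc3cn(Cc4ccccc4Br)nn3)ccc12` carries a 2-bromophenyl group; in this assay compound 1 reaches only the assay limit, > 100000 nM, which is the limit of > 100000 nM in this assay, at which 1 of the 3 values shown sits. Compound 2 `O=c1ccoc2cc(OCc3cn(Cc4cccc(Br)c4)nn3)ccc12` carries the 3-bromophenyl group instead, and in this assay compound 2 gives 17600 nM, the lowest of the two numbers shown, with compound 3 the nearest at a value beyond the scatter above it. For the measured compounds named here, the single measured step, an at least 5.6-fold lower number from compound 1 to compound 2 (0.75 log units; beyond the scatter), shows that where the bromine sits on the phenyl ring matters.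

Compound 4 `O=c1ccoc2cc(OCc3cn(Cc4cccc([N+](=O)[O-])c4)nn3)ccc12` has not yet been measured. It differs from compound 2 by nitro in place of bromo on an aromatic carbon. Going by the values given here, no measured step exchanges one group for another on that ring; the only step available moves the bromine between positions and so does not speak directly to this change. The expected step is therefore no change at the digits printed from compound 2 to compound 4 (within the scatter), nothing beyond the scatter, in no fixed direction. Compound 4 is estimated at 17600 nM, with a range from 6000 nM to 55000 nM.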

Compound 4, half-maximal inhibitory concentration: 14100 nM
Compound 4: the middle estimate sits 1.2-fold (0.10 log units) above what was measured; low and high end bracket the measured number.
By their numbers in this assay, from the lowest: compounds 4 and 2 (each within the scatter of the next); then compound 3. At a limit, above all of these: compound 1.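

In this assay, the exchange on an aromatic carbon, meta to a large group, gives a 1.2-fold lower number from compound 2 to compound 4 (0.10 log units; within the scatter), so bromo and nitro cannot be told apart at this position by this read-out, although they differ in heavy atoms and in hydrogen-bond acceptors. The earlier compounds shown here showed only that moving the bromine matters; the 3-nitrophenyl group now stands level with the 3-bromophenyl group, and the distance from the 2-bromophenyl group remains, with an at least 7.0-fold lower number from compound 1 to compound 4 (0.85 log units; beyond the scatter), a step that changes both the group and where it sits. Compound 1 remains a limit and not a number: the limit of > 100000 nM in this assay, at which 1 of the 4 values shown sits.

From the compounds shown here alone, what stays open is whether a different kind of group on this aromatic carbon, such as an amine or a carboxylic acid, would move the number beyond the scatter, since two groups that give matching numbers say little about the range this position allows. Going by these compounds, it also stays open whether nitro depends on its place on the ring as bromo does, and whether a longer chain carrying either group would keep these numbers.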